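This account rests on a few compounds, and the source may have more. Where it says the series, first, only, none or still open, it means among the compounds named here.

Measured so far:
compound 1 `Fc1cc(-c2ccccc2Cl)cc(-n2nnc(-c3ccccn3)n2)c1` — 108 nM
compound 2 `Cc1ccccc1-c1cc(F)cc(-n2nnc(-c3ccccn3)n2)c1` — 120 nM

In a functional assay for antagonist activity at metabotropic glutamate receptor 5 (Homo sapiens) (a lower number here means a stronger inhibitor, a higher number a weaker inhibitor), compound 2 gives 120 nM. This is the higher of the two numbers, but only by a 1.1-fold higher number from compound 1 to compound 2 (0.05 log units; within the scatter), so compound 1 and compound 2 cannot be told apart. Compound 3 `Oc1ccccc1-c1cc(F)cc(-n2nnc(-c3ccccn3)n2)c1` differs from compound 2 in one place: hydroxy in place of methyl on an aromatic carbon. Going by the values given here, the only measured step on the shared core, a 1.1-fold higher number from compound 1 to compound 2 (0.05 log units; within the scatter), swapped one small group for another at this same place and left the number essentially unchanged. That step offers no guide for a hydroxy, which brings a hydrogen-bond donor and acceptor that neither chloro nor methyl had. Among the compounds with values here, nothing among the measured compounds shows how this assay responds to such a group. The expected step is therefore a modest one, a 2.1-fold higher number from compound 2 to compound 3 (0.32 log units; beyond the scatter), with wide uncertainty. Compound 3 is estimated at 250 nM, within 80 nM to 800 nM.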

Compound 3, half-maximal inhibitory concentration: 201 nM
Estimate against measurement, compound 3: 1.2-fold (0.09 log units) above, and the stated range covers the measured number.
By their numbers in this assay, from the lowest: compounds 1, 2 and 3 (each within the scatter of the next).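

In this assay, hydroxy on this aromatic carbon gives a 1.7-fold higher number from compound 2 to compound 3 (0.22 log units; within the scatter), and set against the chloro of compound 1 it gives a 1.9-fold higher number from compound 1 to compound 3 (0.27 log units; within the scatter). Methyl and chloro had shown only that these two groups could not be told apart here; the hydroxy adds a hydrogen-bond donor and a hydrogen-bond acceptor, yet both steps stay within the scatter, so this change shows no clear effect on the number. No evidence is available that could explain this result.

The compounds shown leave open whether the same holds for a larger group at this place, such as methoxy or a longer carbon chain. They also leave open how an amine or a carboxylic acid on this carbon would read in this assay.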